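This account rests on a few compounds, and the source may have more. Where it says the series, first, only, none or still open, it means among the compounds named here.

Compound 2, `Nc1sc(-c2ccc(Br)cc2)c(-c2ccc(Cl)cc2)c1C(=O)NC1CC1`, gives in a functional assay on A549 cells (Homo sapiens) for cytotoxicity, read by sulforhodamine B assay, with a stated time of 72 h (on this read-out higher numbers stand for weaker inhibition and lower numbers for stronger inhibition), only a limit, > 50000 nM, where the limit of > 50000 nM in this assay, at which 1 of the 2 values shown sits, sits; no number stands for it. Compound 1, `Nc1sc(-c2ccccc2)c(-c2ccc(Cl)cc2)c1C(=O)NCc1ccccc1`, which carries a benzyl on the amide nitrogen and a plain phenyl on the core, gives 8510 nM in this assay. Compound 3, `Nc1sc(-c2ccc(Br)cc2)c(-c2ccc(Cl)cc2)c1C(=O)NCc1ccccc1`, is not yet measured; it differs from compound 2 by benzyl in place of cyclopropyl on an amide-type nitrogen, a benzyl in place of cyclopropyl on an amide-type nitrogen. Since compound 1 with its benzyl shows a measurable 8510 nM, compound 3 is expected to move toward stronger inhibition, a step estimated at an at least 2.5-fold lower number from compound 2 to compound 3 (0.39 log units; beyond the scatter). For compound 3 the estimate is 20000 nM, within 5000 nM to 80000 nM.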

Compound 3, half-maximal inhibitory concentration: 18700 nM
Beside the measured number, compound 3's estimate is 1.1-fold (0.03 log units) above it; measured number inside the range.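

Going by these compounds alone, on the amide-type nitrogen, benzyl in place of cyclopropyl gives in this assay an at least 2.6-fold lower number from compound 2 to compound 3 (0.42 log units; beyond the scatter), the first direct reading of a change at this position. With benzyl kept, bromo in place of hydrogen on an aromatic carbon gives a 2.2-fold higher number from compound 1 to compound 3 (0.34 log units; beyond the scatter), so this change moves toward weaker inhibition. The first step gives only a bound, as compound 2 stands at a limit: the limit of > 50000 nM in this assay, at which 1 of the 3 values shown sits.

As far as these compounds go, whether a longer chain, such as phenethyl, on the amide-type nitrogen would lower the number further remains open. So does how a chloro or methoxy in place of the bromo would read.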